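From 4-fluorophenyl to 2-bromophenyl on a sulfonyl sulfur

The compounds below may be only part of what the source reports. "The series", "measured", "known", "first", "only" and "open" are said of these compounds alone.

Compound 1 `COc1ccc([C@H]2CC(=O)N(c3cccc(O)c3)C2)cc1OC1CCCC1`: > 10000 nM (a limit)
Compound 2 `COc1ccc([C@H]2CC(=O)N(c3cccc(NS(=O)(=O)c4ccc(F)cc4)c3)C2)cc1OC1CCCC1`: > 10000 nM (a limit)

In a functional assay on HEK293 cells (Homo sapiens) for cytotoxicity (on this read-out lower numbers stand for higher toxicity in this test and higher numbers for lower toxicity in this test), compound 2 gives only a limit, > 10000 nM. The record so far is the limit of > 10000 nM in this assay, at which 2 of the 2 values shown sit. Compound 3 `COc1ccc([C@H]2CC(=O)N(c3cccc(NS(=O)(=O)c4ccccc4Br)c3)C2)cc1OC1CCCC1` carries 2-bromophenyl in place of 4-fluorophenyl on a sulfonyl sulfur. Among the compounds with values here, the only measured step that bears on this change is a step that the two limits leave unreadable from compound 1 to compound 2, which offers no size to carry over. The expected step is therefore a step that the limit leaves unreadable from compound 2 to compound 3, with no shift beyond the scatter expected in this assay. Compound 3 is estimated at 15000 nM, with an expected range from 7000 nM to 30000 nM.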

Compound 3, half-maximal cytotoxic concentration: > 10000 nM
Compound 3 was reported as a limit; the forecaster's own chance of this, stated with the estimate: 85%; the middle value is on the limit's open side.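

In this assay compound 3 gives > 10000 nM, which is a limit. Within the data shown here, no step among compound 1, compound 2 and compound 3 can be read from it. The compounds shown leave open how far past this limit each one lies, and so whether either change alters toxicity in this test.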